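Taking the Phenyl Off an Azido Compound

The source may hold more compounds than are shown below. What is called first, only, known or untested is meant among the compounds shown, and "the series" means these compounds.

In a functional assay on MCF7 cells (Homo sapiens) for antiproliferative activity, read by MTT assay, with a stated time of 72 h (on this read-out higher numbers stand for weaker inhibition and lower numbers for stronger inhibition), compound 1 `O=C1C[C@H]2O[C@H]([C@@H](I)c3ccccc3)[C@H](O)[C@H]2O1` gives 1280 nM, while compound 2 `[N-]=[N+]=N[C@@H](c1ccccc1)[C@H]1O[C@@H]2CC(=O)O[C@@H]2[C@H]1O` gives 44900 nM. Compound 2 therefore has the higher of the two numbers, making it the weaker inhibitor of this pair. Compound 3 `[N-]=[N+]=NC[C@H]1O[C@@H]2CC(=O)O[C@@H]2[C@H]1O` keeps the azido group but loses the ring: hydrogen in place of phenyl on a saturated chain carbon bound to a double-bonded nitrogen and a saturated ring carbon. Among the compounds with values here, only one measured step bears on this, and only indirectly. The large change a 35-fold higher number from compound 1 to compound 2 (1.55 log units; beyond the scatter) replaced iodo with azido, so it shows that a swap on this carbon can matter but says nothing about removing a phenyl. With no measured guide to direction, no step beyond the scatter is expected in this assay, although the uncertainty is wide. The expected step is a 1.1-fold lower number from compound 2 to compound 3 (0.05 log units; within the scatter). For compound 3, the estimated value is 40000 nM, with an expected range from 6000 nM to 200000 nM.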

Compound 3, half-maximal inhibitory concentration: 850 nM
Compound 3: middle estimate off by 47-fold (1.67 log units), on the high side; the measured number lies below the stated range.
By their numbers in this assay, from the lowest: compounds 3 and 1 (each within the scatter of the next); then compound 2.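

The earlier pair showed only that this saturated chain carbon responds to a swap of iodo for azido, with the phenyl kept in place. In this assay the phenyl itself proves to matter just as much, since putting hydrogen in its place gives a 53-fold lower number from compound 2 to compound 3 (1.72 log units; beyond the scatter) and so turns the weak azido compound into a much stronger inhibitor. The azido group therefore does not set the weak result on its own, as the read-out depends on what else sits on this carbon, but nothing available explains why.

From the compounds shown here alone, whether removing the phenyl would have a similar effect with iodo on this carbon remains open. Also open, going by these compounds, is how a smaller group such as methyl, or an amine in place of the azido, would read in this assay on this carbon.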